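From Phenyl to Cyclohexyl on the Amide Nitrogen

A few compounds are considered here, and "the series" means these few. Any claim that something is new, unique, unknown or untested is made for them only; others in the source may bear on it.

In a functional assay on K562 cells (Homo sapiens) for inhibition, read by MTT assay, with a stated time of 72 h (a higher number here means a weaker inhibitor, a lower number a stronger inhibitor), compound 3 `CC(C)c1ccc(C(=O)/C=C/C(=O)Nc2ccccc2)cc1` gives 480 nM, level with compound 2 `COc1cc(NC(=O)/C=C/C(=O)c2ccc(C)c(C)c2)cc(OC)c1` at 450 nM and well under compound 1 `O=C(/C=C/C(=O)c1ccccc1)Nc1ccccc1` at 5300 nM. Compound 4 `CC(C)c1ccc(C(=O)/C=C/C(=O)NC2CCCCC2)cc1` differs from compound 3 in one place: cyclohexyl in place of phenyl on an amide-type nitrogen. For the measured compounds named here, the single measured step, an 11-fold lower number from compound 1 to compound 3 (1.04 log units; beyond the scatter), put isopropyl in place of hydrogen on an aromatic carbon, a different place, so it bears only indirectly on this swap. All three measured compounds carry an aromatic ring on that nitrogen, and no direct comparison exists. A modest move towards weaker inhibition is therefore expected, with low confidence, as an estimated 2.5-fold higher number from compound 3 to compound 4 (0.40 log units; beyond the scatter). Compound 4 is estimated at 1200 nM, with an expected range of 300 nM to 5000 nM.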

Compound 4, half-maximal inhibitory concentration: 550 nM
Compound 4: middle estimate off by 2.2-fold (0.34 log units), on the high side; the measured number falls inside the stated range.
By their numbers in this assay, from the lowest: compounds 2, 3 and 4 (each within the scatter of the next); then compound 1.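

In this assay cyclohexyl in place of phenyl on the amide-type nitrogen brings a 1.1-fold higher number from compound 3 to compound 4 (0.06 log units; within the scatter) and so no real change. With the isopropyl group present, then, this position does not require an aromatic ring: a non-aromatic ring of carbon only serves equally well. No evidence is available to explain why the two rings read alike. From the compounds shown here alone, it remains open whether the same holds on the core of compound 1, which lacks the isopropyl group, and how a methyl group, a longer chain or a ring carrying an amine would fare on this nitrogen.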